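Methyl to fluoro on the benzyl ring of compound 3

The source may hold more compounds than are shown below. What is called first, only, known or untested is meant among the compounds shown, and "the series" means these compounds.

Compound 3 `COc1ccc([C@@H]2CC(=O)c3c(O)cc(OCc4cn(Cc5ccc(C)cc5)nn4)cc3O2)cc1O` stands second highest of the three numbers in a functional assay on RAW264.7 cells (Mus musculus) for inhibition, read by Griess assay, with stated times of 2 h and 24 h (on this read-out lower numbers stand for stronger inhibition and higher numbers for weaker inhibition), giving 16800 nM. Compound 1 `COc1ccc([C@@H]2CC(=O)c3c(O)cc(OCc4cn(Cc5cccc(C(F)(F)F)c5)nn4)cc3O2)cc1O` gives 19900 nM and compound 2 `CCn1cc(COc2cc(O)c3c(c2)O[C@H](c2ccc(OC)c(O)c2)CC3=O)nn1` gives 15000 nM. Compound 4 `COc1ccc([C@@H]2CC(=O)c3c(O)cc(OCc4cn(Cc5ccc(F)cc5)nn4)cc3O2)cc1O` differs from compound 3 by fluoro in place of methyl on an aromatic carbon; read one bond further out, the change is 4-methylphenyl to 4-fluorophenyl. The measured steps at the same saturated chain carbon all stayed flat: a 1.2-fold lower number from compound 1 to compound 3 (0.07 log units; within the scatter), a 1.1-fold higher number from compound 2 to compound 3 (0.05 log units; within the scatter) and a 1.3-fold lower number from compound 1 to compound 2 (0.12 log units; within the scatter). Nothing among these three compounds suggests that a change at this aromatic carbon moves this assay beyond its scatter, so no step beyond the scatter is expected for compound 4, whose expected step is a 1.0-fold higher number from compound 3 to compound 4 (0.01 log units; within the scatter). Compound 4 is therefore estimated at 17000 nM, with a range from 9000 nM to 32000 nM.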

Compound 4, half-maximal inhibitory concentration: 15100 nM
Beside the measured number, compound 4's estimate is 1.1-fold (0.05 log units) above it, and the stated range covers the measured number.
By their numbers in this assay, from the lowest: compounds 2, 4, 3 and 1 (each within the scatter of the next).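

In this assay, a change made on the aromatic ring itself, rather than at the saturated chain carbon, also stays within the scatter (a 1.1-fold lower number from compound 3 to compound 4 (0.05 log units; within the scatter)): fluoro in place of methyl, para to a large group, separates neither compound. Compound 4 also stays within the scatter of the two other compounds (a 1.0-fold higher number from compound 2 to compound 4 (0.00 log units; within the scatter); a 1.3-fold lower number from compound 1 to compound 4 (0.12 log units; within the scatter)). No measurement shown here offers an explanation for these small steps. Going by these compounds, whether an amine or a carboxylic acid on this aromatic carbon would move the number beyond the scatter remains open. So does the effect of a longer chain at the saturated chain carbon bound to an aromatic nitrogen.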